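From Iodo to Chloro on the Phenyl Ring of Compound 2

The compounds below may be only part of what the source reports. "The series", "measured", "known", "first", "only" and "open" are said of these compounds alone.

Compound 1, `C=C1CC[C@@H](C(C)C)[C@]12CC=C(C=O)CC2`: 210000 nM
Compound 2, `C=C1CCC[C@]2(C)CCC(c3cn(-c4ccc(I)cc4)nn3)=CC[C@@]12C`: 162000 nM

In a functional assay on MCF7 cells (Homo sapiens) for cytotoxicity, read by MTT assay, with a stated time of 48 h (a higher number here means a weaker inhibitor, a lower number a stronger inhibitor), compound 1 gives 210000 nM and compound 2 gives 162000 nM. Compound 2 holds the lower of the two numbers, but its gap to compound 1 lies within the scatter of repeated measurements, so the two compounds cannot be ordered against each other. Compound 3, `C=C1CCC[C@]2(C)CCC(c3cn(-c4ccc(Cl)cc4)nn3)=CC[C@@]12C`, has not yet been measured in this assay. It differs from compound 2 by chloro in place of iodo on an aromatic carbon. Going by the values given here, no step between measured compounds is available that would show what a halogen exchange of this kind does in this assay, and the two measured numbers give no direction either. A step no larger than the scatter, with no settled direction, is therefore expected from compound 2 to compound 3. Compound 3 is expected to give 200000 nM, with a range from 80000 nM to 500000 nM. The step this estimate implies is a 1.2-fold higher number from compound 2 to compound 3 (0.09 log units; within the scatter).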

Compound 3, half-maximal inhibitory concentration: 35100 nM
The estimate for compound 3 lay 5.7-fold (0.76 log units) above the measured number, and the stated range ends above it.
By their numbers in this assay, from the lowest: compound 3; then compounds 2 and 1 (each within the scatter of the next).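

In this assay, going by these compounds alone, the para halogen of the 4-iodophenyl group proves to be a position that matters: chloro in place of iodo gives a 4.6-fold lower number from compound 2 to compound 3 (0.66 log units; beyond the scatter) and moves the series beyond the scatter for the first time. Compounds 1 and 2 could not show this, since they differ in more than one place and their numbers cannot be ordered against each other. No measurement at hand bears on why this single exchange of one halogen for another changes the number.

Going by these compounds, what remains open is whether the number keeps changing along the halogens, with bromo or fluoro on the same aromatic carbon. Also open, on these data alone, is whether a group of another kind there, such as methoxy or an amine, or a plain phenyl ring, would match or exceed the step seen with chloro.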